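Removing a Fluorine and Shortening the Linker

The source may hold more compounds than are shown below. What is called first, only, known or untested is meant among the compounds shown, and "the series" means these compounds.

Measured compounds:
Compound 1, `O=S(=O)(NCCCNc1nccc(-c2c(-c3cccc(F)c3)nc3sccn23)n1)c1ccc(F)cc1`: in a functional assay on SK-MEL-28 cells (Homo sapiens) for cytotoxicity, read by MTT assay (a lower number here means a stronger inhibitor, a higher number a weaker inhibitor), compound 1 gives > 20000 nM, which is a limit of the assay, not a number.
Compound 2, `O=S(=O)(NCCNc1nccc(-c2c(-c3cccc(F)c3)nc3sccn23)n1)c1ccc(Br)cc1`: in this assay compound 2 gives 13500 nM.
Compound 3, `Cc1ccc(S(=O)(=O)NCCNc2nccc(-c3c(-c4cccc(F)c4)nc4sccn34)n2)cc1`: in this assay compound 3 gives > 20000 nM, again a limit of the assay rather than a number.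

Compound 1 therefore stands only at a limit, and it shares that position with one other compound, since (the limit of > 20000 nM in this assay, at which 2 of the 3 values shown sit). The unmeasured compound 4, `O=S(=O)(NCCNc1nccc(-c2c(-c3cccc(F)c3)nc3sccn23)n1)c1ccccc1`, differs from compound 1 in one place: (phenylsulfonyl)amino in place of (((4-fluorophenyl)sulfonyl)amino)methyl on a saturated chain carbon, two bonds along the chain from a nitrogen on an aromatic ring.

Among the compounds with values here, two measured steps bear on this change. The step of an at least 1.4-fold lower number from compound 1 to compound 2 (0.17 log units; that floor lies within the scatter) also shortens the chain and swaps the group on the ring, and its floor lies within the usual scatter. The step that the two limits leave unreadable from compound 1 to compound 3 gives no readable size at all. Between the two shorter-chain compounds, the step of an at least 1.4-fold higher number from compound 2 to compound 3 (0.17 log units; that floor lies within the scatter) again has a floor within the scatter. Nothing here points to a move beyond the scatter in either direction in this assay, and a further limit is the likeliest outcome.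

Compound 4 is therefore expected to give about 20000 nM, within a range from 8000 nM to 50000 nM, so the expected step is a number no higher from compound 1 to compound 4 (the limit leaves the size open).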

Compound 4, half-maximal inhibitory concentration: 19000 nM
The estimate for compound 4 lay 1.1-fold (0.02 log units) above the measured number; the range from low to high includes it.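

The step that replaces bromo with hydrogen on the ring is a 1.4-fold higher number from compound 2 to compound 4 (0.15 log units; within the scatter), so in this assay this place on the ring shows no readable preference between these two groups. The step with hydrogen in place of methyl on the same carbon is an at least 1.0-fold lower number from compound 3 to compound 4 (0.02 log units; that floor lies within the scatter), and the step that brings in (phenylsulfonyl)amino is an at least 1.0-fold lower number from compound 1 to compound 4 (0.02 log units; that floor lies within the scatter). Both of these steps start from a limit of the assay rather than a number, so each gives only a floor, and the values shown still include a limit: the limit of > 20000 nM in this assay, at which 2 of the 4 values shown sit.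

Going by these compounds, whether an amine or a carboxylic acid in place of bromo on that aromatic carbon would move the number beyond the scatter remains open. The compounds shown also do not separate the length of the chain from the group on the ring, so what the chain alone contributes in this assay cannot be read.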